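Thiophene Attachment Shift in a Fused Bicyclic Series

The source may hold more compounds than are shown below. What is called first, only, known or untested is meant among the compounds shown, and "the series" means these compounds.

Compound 1 `Cc1cc(-c2nc3n(c2/C=N/NC(=N)N)CCS3)c(C)s1`: 30900 nM
Compound 2 `N=C(N)N/N=C/c1c(-c2cccs2)nc2sccn12`: 24500 nM

Compound 1 `Cc1cc(-c2nc3n(c2/C=N/NC(=N)N)CCS3)c(C)s1` and compound 2 `N=C(N)N/N=C/c1c(-c2cccs2)nc2sccn12` were both tested in a functional assay on cells (Cancer cell lines, Homo sapiens) for inhibition; a higher number here means a weaker inhibitor of growth, a lower number a stronger inhibitor of growth. In this assay compound 1 gives 30900 nM, and compound 2 gives 24500 nM; the two values lie within the scatter of each other, so neither compound stands apart. Compound 3 `N=C(N)N/N=C/c1c(-c2ccsc2)nc2sccn12` has not yet been measured. It differs from compound 2 by thiophen-3-yl in place of thiophen-2-yl on an aromatic carbon. Among the measured compounds shown here, with no measured step to set the size, the change is expected to produce no step beyond the scatter in this assay. Compound 3 is therefore estimated at 25000 nM, within 10000 nM to 60000 nM, an expected step of a 1.0-fold higher number from compound 2 to compound 3 (0.01 log units; within the scatter).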

Compound 3, concentration for total growth inhibition: 28800 nM
Compound 3: the middle estimate sits 1.2-fold (0.06 log units) below what was measured; low and high end bracket the measured number.
By their numbers in this assay, from the lowest: compounds 2, 3 and 1 (each within the scatter of the next).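

In this assay, among the compounds shown here, thiophen-3-yl in place of thiophen-2-yl gives a 1.2-fold higher number from compound 2 to compound 3 (0.07 log units; within the scatter), the only step measured at this position. Where the thiophene ring is attached therefore does not separate these two compounds in this assay, and this single pair sets no size for larger changes here. No supporting measurement bears on this result. As far as these compounds go, whether a phenyl ring, an amine or a carboxylic acid at this position would give a step beyond the scatter remains open.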